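Swapping the propyl on the ring nitrogen for ethylsulfonyl

The compounds below may be only part of what the source reports. "The series", "measured", "known", "first", "only" and "open" are said of these compounds alone.

Measured compounds:
- compound 1, `CC(C)(C)c1ccc(NC(=O)c2ccc(-c3ccccn3)cc2)cc1`: 11 nM
- compound 2, `CCCOc1cccnc1-c1ccc(C(=O)Nc2ccc(C(C)(C)C)cc2)cc1`: 62 nM
- compound 3, `CCCNc1cccnc1-c1ccc(C(=O)Nc2ccc(C(C)(C)C)cc2)cc1`: 158 nM

All three share one core and differ only in what sits on a single aromatic carbon. In a functional assay for antagonist activity at transient receptor potential cation channel subfamily V member 1 (Homo sapiens), read by FLIPR (on this read-out lower numbers stand for stronger inhibition and higher numbers for weaker inhibition), compound 3 gives the highest number of the three, so it is the weakest of this small set. Going from hydrogen to propylamino gave a 14-fold higher number from compound 1 to compound 3 (1.16 log units; beyond the scatter), and exchanging propoxy for propylamino gave a 2.5-fold higher number from compound 2 to compound 3 (0.41 log units; beyond the scatter), so both substituted compounds sit clearly behind compound 1.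

Compound 4, `CCS(=O)(=O)Nc1cccnc1-c1ccc(C(=O)Nc2ccc(C(C)(C)C)cc2)cc1`, is the next step: ethylsulfonyl in place of propyl on a nitrogen on an aromatic ring. The nitrogen stays attached to the ring; only what hangs on it changes. Going by the values given here, no measured pair shows this kind of exchange, so the steps that bear on it do so only loosely. They show that adding a propyl-bearing group at this position costs potency, and that the two such groups differ from each other by a modest amount. Replacing propyl with ethylsulfonyl is a larger change than either of those, and its direction cannot be read from the data. A step of modest size in this assay toward a higher number is expected for compound 4, with wide uncertainty, giving a 1.9-fold higher number from compound 3 to compound 4 (0.28 log units; within the scatter). Compound 4 is therefore estimated at 300 nM, within 60 nM to 1500 nM.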

Compound 4, half-maximal inhibitory concentration: 49 nM
For compound 4 the middle estimate is 6.1-fold (0.79 log units) above the measured one; measured number below the stated range.
By their numbers in this assay, from the lowest: compound 1; then compounds 4 and 2 (each within the scatter of the next); then compound 3.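

In this assay, going by these compounds alone, the earlier compounds left open whether the nitrogen on the aromatic ring settles the result on its own, but putting ethylsulfonyl on that same nitrogen in place of propyl gives a 3.2-fold lower number from compound 3 to compound 4 (0.51 log units; beyond the scatter), so what hangs on the nitrogen clearly matters. Set against the propoxy group, the (ethylsulfonyl)amino group gives a 1.3-fold lower number from compound 2 to compound 4 (0.10 log units; within the scatter), so the two compounds cannot be told apart here, and a substituent with a sulfonyl group does as well as one joined through oxygen, though the substituent still carries a cost, with a 4.5-fold higher number from compound 1 to compound 4 (0.65 log units; beyond the scatter), leaving hydrogen on this aromatic carbon the best of the four groups shown. Nothing at hand explains why this exchange moves the number as it does.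

The compounds shown leave open whether the gain belongs to the sulfonyl group itself or to the ethyl on it, which a methylsulfonyl, a longer alkylsulfonyl chain or an acetyl on the same nitrogen could help separate. They also leave open how a plain amino group on this aromatic carbon, with nothing on the nitrogen, would compare with hydrogen.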